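Cyclopentyl in Place of Propyl: Expected Cytotoxicity Shift

A few compounds are considered here, and "the series" means these few. Any claim that something is new, unique, unknown or untested is made for them only; others in the source may bear on it.

Measured compounds:
compound 1 `CCCC(=O)Nc1ccn([C@@H]2CO[C@H](CO)O2)c(=O)n1`, 8070 nM
compound 2 `CCCCCCCCCCCCCCCC(=O)Nc1ccn([C@@H]2CO[C@H](CO)O2)c(=O)n1`, 20 nM
compound 3 `CCCCCCCCCCCCCCCCCCCCCC(=O)Nc1ccn([C@@H]2CO[C@H](CO)O2)c(=O)n1`, 900 nM

In a functional assay on SW1573 cells (Homo sapiens) for cytotoxicity, read by sulforhodamine B assay, with a stated time of 72 h (on this read-out lower numbers stand for stronger inhibition and higher numbers for weaker inhibition), compound 1 gives the highest of the three numbers; compound 3 sits below it and compound 2 gives the lowest. Compound 4 `O=C(Nc1ccn([C@@H]2CO[C@H](CO)O2)c(=O)n1)C1CCCC1` carries cyclopentyl in place of propyl on a carbonyl carbon. Among the compounds with values here, only one measured step is known, a 45-fold higher number from compound 2 to compound 3 (1.65 log units; beyond the scatter), which concerns a far longer chain and bears on this change only loosely. Compound 1 and compound 2 show that a longer chain on the carbonyl carbon goes with a much lower number, and compound 4 adds two carbons in a ring. A modest move downward is therefore expected for compound 4, a 2.0-fold lower number from compound 1 to compound 4 (0.30 log units; within the scatter). Compound 4 is estimated at 4000 nM, within 1500 nM to 12000 nM.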

Compound 4, half-maximal inhibitory concentration: 8800 nM
For compound 4 the middle estimate is 2.2-fold (0.34 log units) below the measured one, within the range that was stated.
By their numbers in this assay, from the lowest: compound 2; then compound 3; then compounds 1 and 4 (each within the scatter of the next).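

In this assay, cyclopentyl in place of propyl on a carbonyl carbon brings no change beyond the scatter (a 1.1-fold higher number from compound 1 to compound 4 (0.04 log units; within the scatter)). At this place, then, the two extra carbons of a five-membered ring do not reproduce what the long chain of compound 2 shows at 20 nM. Nothing at hand accounts for this result. From the compounds shown here alone, it remains open whether cyclohexyl or phenyl on this carbonyl carbon would behave like cyclopentyl. Also open, going by these compounds, is how an octyl or decyl chain there would compare with propyl.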